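Cytotoxicity limits and the amide-nitrogen change in compound 3

The compounds below may be only part of what the source reports. "The series", "measured", "known", "first", "only" and "open" are said of these compounds alone.

In an ADME assay on Huh-7 cells (Homo sapiens) for cytotoxicity, read by a luciferase reporter and WST assay, with a stated time of 3 days (a higher number here means that more compound is tolerated, a lower number that less compound is tolerated), compound 1 `Cc1ccc(NC(=O)c2c(NO)cc(-c3ccc(C)cc3)oc2=O)cc1` gives > 20000 nM, which is a limit and not a number. Compound 2 `COc1ccc(-c2cc(NO)c(C(=O)Nc3ccc(C)cc3)c(=O)o2)cc1` gives > 20000 nM, again a limit. Thus (the limit of > 20000 nM in this assay, at which 2 of the 2 values shown sit). Compound 3 `CNC(=O)c1c(NO)cc(-c2ccc(C)cc2)oc1=O` carries methyl in place of 4-methylphenyl on an amide-type nitrogen. Going by the values given here, the only measured step, a step that the two limits leave unreadable from compound 1 to compound 2, is methoxy in place of methyl on an aromatic carbon, so it concerns another place and gives no size to carry over. No step beyond the scatter is expected in this assay, and no direction can be assigned. The expected change is a step that the limit leaves unreadable from compound 1 to compound 3. For compound 3 the estimate is 30000 nM, with an expected range of 12000 nM to 80000 nM.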

Compound 3, half-maximal cytotoxic concentration: > 20000 nM
Compound 3: no number, only a limit; the forecaster's own chance of this, stated with the estimate: 75%; the middle value lies beyond the limit too.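

Compound 1 and compound 3 both give only a limit, and no step can be read between them: the limit of > 20000 nM in this assay, at which 3 of the 3 values shown sit.
Left open is the concentration at which these compounds become cytotoxic, and whether methyl in place of 4-methylphenyl on the amide-type nitrogen changes it.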